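A Pyridinyl Amide Tested Against Fluorinated Anilides

This account rests on a few compounds, and the source may have more. Where it says the series, first, only, none or still open, it means among the compounds named here.

Compound 3 `O=C(CCCCCCNC(=O)C(O)(O)C(F)(F)F)Nc1ccc(F)cc1F` gives 18500 nM in a functional assay on HCT-116 cells (Homo sapiens) for inhibition, read by colorimetric assay, with a stated time of 3 days (a higher number here means a weaker inhibitor, a lower number a stronger inhibitor), the highest number among the three measured compounds. Compound 2 `O=C(CCCCCCNC(=O)C(O)(O)C(F)(F)F)Nc1ccc(F)cc1` gives 7570 nM, and compound 1 `O=C(CCCCCCNC(=O)C(O)(O)C(F)(F)F)Nc1nc2ccccc2s1` gives 2370 nM. Compound 4 `O=C(CCCCCCNC(=O)C(O)(O)C(F)(F)F)Nc1ccncc1` differs from compound 3 in one place: pyridin-4-yl in place of 2,4-difluorophenyl on an amide-type nitrogen. Among the measured compounds shown here, no measured step exchanges an aryl group for pyridin-4-yl, so the bearing steps are indirect. Adding fluoro gave a 2.4-fold higher number from compound 2 to compound 3 (0.39 log units; beyond the scatter), and the aryl exchanges gave a 3.2-fold higher number from compound 1 to compound 2 (0.50 log units; beyond the scatter) and a 7.8-fold higher number from compound 1 to compound 3 (0.89 log units; beyond the scatter). Going by these compounds, removing both fluorines would be expected to undo a modest part of that rise, while the pyridin-4-yl itself remains untested, so compound 4 is expected to give 8000 nM, within 2500 nM to 25000 nM, a step of a 2.3-fold lower number from compound 3 to compound 4 (0.36 log units; beyond the scatter) that is expected to be small.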

Compound 4, half-maximal inhibitory concentration: 6670 nM
For compound 4 the middle estimate is 1.2-fold (0.08 log units) above the measured one; the measured number falls inside the stated range.
By their numbers in this assay, from the lowest: compound 1; then compounds 4 and 2 (each within the scatter of the next); then compound 3.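

In this assay, pyridin-4-yl on the amide-type nitrogen cannot be told apart from 4-fluorophenyl (a 1.1-fold lower number from compound 2 to compound 4 (0.05 log units; within the scatter)), yet it gives a lower number than 2,4-difluorophenyl (a 2.8-fold lower number from compound 3 to compound 4 (0.44 log units; beyond the scatter)). A ring nitrogen is therefore compatible with activity in this series, although 1,3-benzothiazol-2-yl keeps the lowest number (a 2.8-fold higher number from compound 1 to compound 4 (0.45 log units; beyond the scatter)). Nothing available here accounts for these differences.

The compounds shown leave open how pyridin-3-yl or 4-aminophenyl would behave on this nitrogen. They also leave open whether a longer chain would shift these numbers.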